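Swapping a nitrile for trifluoromethyl on a shared core

This account rests on a few compounds, and the source may have more. Where it says the series, first, only, none or still open, it means among the compounds named here.

Within the data shown here, compound 2 `N#Cc1cc(NCc2ccccc2[N+](=O)[O-])c2cn[nH]c2c1` stands highest of the two numbers so far in an assay for inhibition of Tryptophan 2,3-dioxygenase (Homo sapiens), with stated times of 10 min and 60 min, tested at 100 uM (a lower number here means a weaker effect, a higher number a stronger effect of the compound at the concentration tested), giving 41%. Its nearest neighbour, compound 1 `NCCn1ncc2c(NCc3ccccc3[N+](=O)[O-])cc(C(F)(F)F)cc21`, gives 29%, a gap beyond the usual scatter. Compound 3 `O=[N+]([O-])c1ccccc1CNc1cc(C(F)(F)F)cc2[nH]ncc12` is not yet measured; it differs from compound 2 by trifluoromethyl in place of cyano on an aromatic carbon. Among the measured compounds shown here, no step between measured compounds is recorded for this change, so only a modest move is expected, most likely downward, and possibly no further than the scatter. For compound 3 the expected result is 33%, in a range from 15% to 50%, meaning an estimated step of a number 8 percentage points lower from compound 2 to compound 3 (within the scatter).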

Compound 3, a percentage reported as inhibition, at one concentration (the size of the read-out at that concentration, not a potency): 95%
Beside the measured number, compound 3's estimate is 62 percentage points below it; measured number outside the range, above it.
By their numbers in this assay, from the lowest: compound 1; then compound 2; then compound 3.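

In this assay the group on this aromatic carbon turns out to matter greatly: trifluoromethyl in place of cyano brings a number 54 percentage points higher from compound 2 to compound 3 (beyond the scatter) on the shared core. The aromatic nitrogen matters as well, since hydrogen in place of 2-aminoethyl brings a number 66 percentage points higher from compound 1 to compound 3 (beyond the scatter) with trifluoromethyl present in both compounds. From the compounds shown here alone, whether a methyl group, a chlorine atom or a carboxylic acid on that same carbon would keep the number this high remains open. What lies behind these two steps has no measurement here.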